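The compounds below may be only part of what the source reports. "The series", "measured", "known", "first", "only" and "open" are said of these compounds alone.

Values measured in a functional assay on A549 cells (Homo sapiens) for inhibition, read by MTT assay, with a stated time of 48 h; on this read-out higher numbers stand for weaker inhibition and lower numbers for stronger inhibition:

- Compound 1 `COc1ccc(N(C)c2nc(C)nc3ccccc23)cc1OCCC[Se]C#N`: 382 nM
- Compound 2 `COc1ccc(N(C)c2nc(C)nc3ccccc23)cc1C(=O)OCCCC[Se]C#N`: 155 nM
- Compound 3 `COc1ccc(N(C)c2nc(C)nc3ccccc23)cc1OCCCC[Se]C#N`: 1200 nM

Compound 3, at 1200 nM, has the highest number of the three and is the weakest inhibitor in this small set. The next compound to consider is compound 4 `COc1ccc(N(C)c2nc(C)nc3ccccc23)cc1C[Se]C#N`, which has not yet been measured. Its change is made on an aromatic carbon of a six-membered aromatic ring of carbon only, ortho to a methoxy group and meta to a large group: a group of 4 heavy atoms (2 carbon, 1 nitrogen, 1 selenium; no ring) in place of a group of 8 heavy atoms (5 carbon, 1 nitrogen, 1 oxygen, 1 selenium; no ring), on an aromatic carbon.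

Among the measured compounds shown here, two measured steps bear on this site. The chain change shows a 3.1-fold higher number from compound 1 to compound 3 (0.50 log units; beyond the scatter), and the exchange of the larger group shows a 7.7-fold higher number from compound 2 to compound 3 (0.89 log units; beyond the scatter). Both end at compound 3 with a higher number, so the other groups tried at this site have so far given lower numbers. For the measured compounds named here, neither step, however, reaches a group as small as the one in compound 4, so the data cover this change only indirectly. A modest step toward a lower number is therefore expected in this assay, with wide uncertainty, and a result near compound 3 would not be surprising.

The expected change is a 3.4-fold lower number from compound 3 to compound 4 (0.54 log units; beyond the scatter). The estimate for compound 4 is 350 nM, with an expected range from 100 nM to 1200 nM.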

Compound 4, half-maximal inhibitory concentration: 98 nM
For compound 4 the middle estimate is 3.6-fold (0.55 log units) above the measured one; measured number outside the range, below it.
By their numbers in this assay, from the lowest: compounds 4 and 2 (each within the scatter of the next); then compound 1; then compound 3.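

In this assay, the group of 4 heavy atoms on this aromatic carbon, ortho to a methoxy group, brings a large gain, a 12-fold lower number from compound 3 to compound 4 (1.09 log units; beyond the scatter), so a group much smaller than those seen earlier is well tolerated here and can match the best of them. It lies within the scatter of the largest group at this site, a 1.6-fold lower number from compound 2 to compound 4 (0.20 log units; within the scatter), yet stands clear of the group of 7 heavy atoms, a 3.9-fold lower number from compound 1 to compound 4 (0.59 log units; beyond the scatter), so the numbers do not follow group size in one direction: compounds 2 and 4, with the largest and smallest groups, share the low end, while compounds 1 and 3, with the intermediate groups, sit higher. Nothing in the data shown accounts for this uneven pattern.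

The compounds shown leave open how a longer chain joined directly to the aromatic carbon, without the oxygen, would compare, and whether an amide would serve in place of the ester-linked chain of compound 2. They also leave open whether the selenium is needed, as a sulfur atom in its place or a simple nitrile on the same carbon would show.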